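The source may hold more compounds than are shown below. What is called first, only, known or untested is meant among the compounds shown, and "the series" means these compounds.

Compound 1, `COc1ccc2nc(C)cc(OCC(=O)Nc3cccc(C)c3)c2c1`, gives 39800 nM in a toxicity assay on HepG2 cells (Homo sapiens) for inhibition, read by CellTiter-Glo, with a stated time of 48 h; a lower number here means a stronger inhibitor, a higher number a weaker inhibitor. Compound 2, `COc1ccc2nc(C)cc(OCC(=O)Nc3cc(C)c(F)c(C)c3)c2c1`, reaches only the limit > 100000 nM in this assay. Compound 3, `COc1ccc2nc(C)cc(OCC(=O)Nc3ccc(Cl)cc3Cl)c2c1`, likewise stops at the limit > 100000 nM in this assay.

Compound 3 therefore has no number of its own in this assay, only a limit, and it shares that limit with compound 2 (the limit of > 100000 nM in this assay, at which 2 of the 3 values shown sit). Compound 4, `COc1ccc2nc(C)cc(OCC(=O)Nc3ccc(Cl)c(OC)c3)c2c1`, differs from compound 3 in one place: 4-chloro-3-methoxyphenyl in place of 2,4-dichlorophenyl on an amide-type nitrogen. Within the data shown here, two measured steps bear on this kind of exchange, both starting from compound 1: an at least 2.5-fold higher number from compound 1 to compound 2 (0.40 log units; beyond the scatter) and an at least 2.5-fold higher number from compound 1 to compound 3 (0.40 log units; beyond the scatter). Each swap of the group on the amide-type nitrogen pushed the value from a readable number to the limit. The step from compound 2 to compound 3 is a step that the two limits leave unreadable from compound 2 to compound 3. For compound 4 an estimate of 80000 nM is expected, with a range from 30000 nM to 200000 nM. This expected step an at least 1.2-fold lower number from compound 3 to compound 4 (0.09 log units; that floor lies within the scatter) would mean compound 4 stays near the limit, though a readable number cannot be ruled out.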

Compound 4, half-maximal inhibitory concentration: > 100000 nM
Compound 4 was reported as a limit; the forecaster's own chance of this, stated with the estimate: 55%; middle value at least 1.2-fold (0.09 log units) away from the limit.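

In this assay, swapping 3-methylphenyl on the amide-type nitrogen for 4-chloro-3-methoxyphenyl gives an at least 2.5-fold higher number from compound 1 to compound 4 (0.40 log units; beyond the scatter). This is the third different group at this position to leave compound 1's readable number for a limit, and unlike 2,4-dichlorophenyl it carries a hydrogen-bond acceptor, so adding that acceptor in place of the 2,4-dichlorophenyl group does not bring back a readable number. The steps among compound 2, compound 3 and compound 4 cannot be read, because all three stop at the same limit rather than a number: the limit of > 100000 nM in this assay, at which 3 of the 4 values shown sit.

From the compounds shown here alone, it remains open whether an amine or a carboxylic acid on this ring would give a lower number than compound 1, at 39800 nM. Going by these compounds, the true values of compound 2, compound 3 and compound 4 also remain unknown, and no order among them can be given.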